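Capping the Hydroxy: From Compound 2 to Compound 4

The source may hold more compounds than are shown below. What is called first, only, known or untested is meant among the compounds shown, and "the series" means these compounds.

Measured compounds:
Compound 1, `COc1ccc(-c2snnc2-c2cc(OC)c(OC)c(OC)c2)cc1`: 14.5 nM
Compound 2, `COc1ccc(-c2snnc2-c2cc(OC)c(OC)c(OC)c2)cc1O`: 1.5 nM
Compound 3, `COc1cc(-c2nnsc2-c2ccc(Cl)cc2)cc(OC)c1OC`: 23.6 nM

In a functional assay on HL-60 cells (Homo sapiens) for antiproliferative activity (a higher number here means a weaker inhibitor, a lower number a stronger inhibitor), compound 2 gives 1.5 nM, the lowest of the three numbers, beyond the scatter from both other compounds. Among the measured compounds shown here, the change a 9.7-fold lower number from compound 1 to compound 2 (0.99 log units; beyond the scatter), hydroxy in place of hydrogen on an aromatic carbon, is the only step here that moved the number; the change a 1.6-fold higher number from compound 1 to compound 3 (0.21 log units; within the scatter) stayed within the scatter. Compound 4 `COc1ccc(-c2snnc2-c2cc(OC)c(OC)c(OC)c2)cc1OC` differs from compound 2 by methyl in place of hydrogen on an oxygen on an aromatic ring. With the hydroxy hydrogen replaced, compound 4 carries a methoxy where compound 1 carries hydrogen, so the gain of compound 2 over compound 1 may not carry over. The step of a 6.0-fold higher number from compound 2 to compound 4 (0.78 log units; beyond the scatter) is therefore expected to raise the number, and compound 4 is estimated at 9 nM, within 3 nM to 30 nM.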

Compound 4, half-maximal inhibitory concentration: 60.9 nM
The estimate for compound 4 lay 6.8-fold (0.83 log units) below the measured number; the whole stated range lies below it.
By their numbers in this assay, from the lowest: compound 2; then compounds 1 and 3 (each within the scatter of the next); then compound 4.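

In this assay, putting a methyl on the oxygen of the hydroxy does more than cancel the earlier gain (a 41-fold higher number from compound 2 to compound 4 (1.61 log units; beyond the scatter)). The resulting methoxy also falls behind plain hydrogen at this place on the ring (a 4.2-fold higher number from compound 1 to compound 4 (0.62 log units; beyond the scatter)), so hydroxy and methoxy move the number in opposite directions from hydrogen. Nothing available here explains this difference. Still open, as far as these compounds go, is whether the gain depends on the hydrogen on that oxygen or on the hydroxy as a whole. An amine at this place, or an ethoxy, could help separate the two.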